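This account rests on a few compounds, and the source may have more. Where it says the series, first, only, none or still open, it means among the compounds named here.

Of the compounds shown here, three have so far been measured in a functional assay on HeLa cells (Homo sapiens) for antiproliferative activity, read by MTT assay, with a stated time of 72 h; a lower number here means a stronger inhibitor, a higher number a weaker inhibitor. Compound 1 `CCN(CC)C(=S)SCC1=CCOC1=O` gives 1390 nM in this assay. Compound 3 `CN1CCN(C(=S)SCC2=CCOC2=O)CC1` gives 770 nM in this assay, a value that lies within the usual scatter of the value of compound 1. Compound 2 `O=C1CC2(CO1)CSC(=S)N2c1ccccc1`, which has a different core, gives 18000 nM in this assay, a clearly higher number than compound 1, so compound 2 is the weaker inhibitor of that pair. Among the three numbers, that of compound 1 is the second highest.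

Compound 4 `CCNC(=S)SCC1=CCOC1=O` has not yet been measured. It differs from compound 1 in one place: hydrogen in place of ethyl on an amide-type nitrogen. Within the data shown here, no measured pair shows this exact change, so its size cannot be read from the data. Compound 1 and compound 3 differ only in the amine attached to the thiocarbonyl carbon and sit within scatter of each other, which gives no reason to expect a large move here. The expected step is a 1.4-fold higher number from compound 1 to compound 4 (0.16 log units; within the scatter), small and, if anything, toward a slightly higher number. Compound 4 is therefore estimated to give about 2000 nM in this assay, with a likely range from 700 nM to 6000 nM.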

Compound 4, half-maximal inhibitory concentration: "not active" (no number reported)
Compound 4 has no reported number here, and the estimate cannot be compared.
By their numbers in this assay, from the lowest: compounds 3 and 1 (each within the scatter of the next); then compound 2.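

Among these compounds, compound 4 is reported as "not active" without a number, so no step from compound 1 to compound 4 can be read. The compounds shown leave open how far diethylamino to ethylamino alone moves the result in this assay in numerical terms. Nothing measured here offers an explanation for this result.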